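This account rests on a few compounds, and the source may have more. Where it says the series, first, only, none or still open, it means among the compounds named here.

Of the compounds shown here, two built on the same core have been measured in a functional assay on the whole organism for inhibition, with Rattus norvegicus as the target, at a dose of 1 mg/kg by the oral route (a lower number here means a weaker effect, a higher number a stronger effect of the compound at the dose given), and each carries its own group on that core. Compound 1 `O=C(Nc1nn[nH]n1)c1cc(Br)ccn1` gives 9% in this assay, while compound 2 `O=C(Nc1nn[nH]n1)c1cccc(/C=C/c2ccccc2)n1` gives 53%. Within the data shown here, of these two numbers compound 1 stands at the lower one, and the gap of compound 2 above it lies beyond the usual scatter; no step between this pair has been worked out, so nothing more than the two values themselves is drawn from them.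

Compound 3 `O=C(Nc1nn[nH]n1)c1ccccn1` has not yet been measured. It differs from compound 1 by hydrogen in place of bromo on an aromatic carbon, a change that takes away a single bromine atom and leaves the rest of the molecule untouched. The bromo sat on an aromatic carbon of a six-membered aromatic ring with 1 nitrogen, opposite the ring nitrogen. Compound 1 is already weak here, with 9% in this assay, and removing one small group gives little reason to expect a large move in either direction. The step from a number 1 percentage points lower from compound 1 to compound 3 (within the scatter) is therefore expected to stay within the scatter. Compound 3 is estimated to reach 8% in this assay, with a likely range from 0% to 25%.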

Compound 3, a percentage reported as inhibition, in the whole organism at one dose (the size of the read-out at that dose, not a potency): 0%
Estimate against measurement, compound 3: 8 percentage points above, within the range that was stated.
By their numbers in this assay, from the lowest: compounds 3 and 1 (each within the scatter of the next); then compound 2.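

Replacing the bromo with hydrogen, on an aromatic carbon opposite the ring nitrogen, gives a number 9 percentage points lower from compound 1 to compound 3 (within the scatter) in this assay. Among these compounds, this is the first direct comparison at this position, and it shows that in this assay compound 1 and compound 3 cannot be told apart: at the dose given, the presence or absence of this single bromine atom makes no difference larger than the usual variation between repeated measurements. No measurement shown here gives a reason for this result.

The comparison covers only bromo and hydrogen on this one aromatic carbon, so it cannot show whether a larger or different group there, such as an amine, a methoxy group, a carboxylic acid or a longer chain, would change the result in this assay. Going by these compounds, because both compounds give low numbers, it also remains open whether this position matters on molecules with a higher read-out, as a single pair of weak compounds says nothing about how the same change would behave elsewhere.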